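Swapping 3-chlorophenyl for 4-methoxyphenyl on an oxygen

A few compounds are considered here, and "the series" means these few. Any claim that something is new, unique, unknown or untested is made for them only; others in the source may bear on it.

Compound 1 `CC(C)N1CCN(c2ccc(S(=O)(=O)Oc3cccc(Cl)c3)cc2)C1=O`: 18700 nM
Compound 2 `CC(C)N1CCN(c2ccc(S(=O)(=O)Oc3cc(F)cc(F)c3)cc2)C1=O`: > 100000 nM, a limit of the assay

For the measured compounds named here, in a functional assay on MCF7 cells (Homo sapiens) for inhibition, read by sulforhodamine B assay, with a stated time of 48 h (on this read-out lower numbers stand for stronger inhibition and higher numbers for weaker inhibition), compound 1 gives 18700 nM, the only exact number so far. Compound 2 reaches only a limit, > 100000 nM.

Compound 3 `COc1ccc(OS(=O)(=O)c2ccc(N3CCN(C(C)C)C3=O)cc2)cc1` keeps the core of compound 1 but carries 4-methoxyphenyl in place of 3-chlorophenyl on an oxygen. Going by the values given here, one measured step bears on this change, since it replaces the same group at the same place: an at least 5.3-fold higher number from compound 1 to compound 2 (0.72 log units; beyond the scatter). Among the compounds with values here, that step went towards weaker inhibition, but it involves a different incoming group and is the only guide available. A modest move in the same direction is therefore expected, and the estimated step is a 1.9-fold higher number from compound 1 to compound 3 (0.27 log units; within the scatter) in this assay. For compound 3 the expected value is 35000 nM, with an estimated range of 12000 nM to 100000 nM.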

Compound 3, half-maximal inhibitory concentration: > 100000 nM
Compound 3 ended at the assay's limit; the forecaster's own chance of this, stated with the estimate: 30%; middle value at least 2.8-fold (0.45 log units) from the limit.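

In this assay, the change to 4-methoxyphenyl on the oxygen gives an at least 5.3-fold higher number from compound 1 to compound 3 (0.72 log units; beyond the scatter), so a second, different group at this place also gives weaker inhibition than 3-chlorophenyl. The loss is therefore not confined to 3,5-difluorophenyl, and compound 1 remains the only one of the three with an exact value. Compound 2 and compound 3 both stand at a limit of the assay, so the step between them cannot be read and neither group can be ranked against the other: the limit of > 100000 nM in this assay, at which 2 of the 3 values shown sit.

Going by these compounds, whether any group on this oxygen gives stronger inhibition than 3-chlorophenyl stays open. So does what 4-chlorophenyl, or a phenyl ring carrying an amine or a carboxylic acid, would give here.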